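From 2-phenylethenyl to 4-nitrophenyl on the shared core

The compounds below may be only part of what the source reports. "The series", "measured", "known", "first", "only" and "open" are said of these compounds alone.

In a functional assay on Ehrlich cells (Mus musculus) for antiproliferative activity, read by trypan blue exclusion, with a stated time of 2 h (on this read-out higher numbers stand for weaker inhibition and lower numbers for stronger inhibition), compound 1 `N#CC1=C(N)N(c2ccc(S(N)(=O)=O)cc2)C2=C(C(=O)CCC2)C1c1ccccc1` gives > 100 ug/mL, which is a limit of the assay and not a number. Compound 2 `N#CC1=C(N)N(c2ccc(S(N)(=O)=O)cc2)C2=C(C(=O)CCC2)C1/C=C/c1ccccc1` gives > 100 ug/mL in this assay, and this too is a limit. Compound 2 therefore has no number of its own, and the picture so far is the limit of > 100 ug/mL in this assay, at which 2 of the 2 values shown sit.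

Compound 3 `N#CC1=C(N)N(c2ccc(S(N)(=O)=O)cc2)C2=C(C(=O)CCC2)C1c1ccc([N+](=O)[O-])cc1` carries 4-nitrophenyl in place of 2-phenylethenyl on a saturated ring carbon.

For the measured compounds named here, the only measured step that bears on this change is a step that the two limits leave unreadable from compound 1 to compound 2, which swaps phenyl for 2-phenylethenyl at that same carbon. It offers no size to carry over, so no shift beyond the scatter is expected in this assay. The expected step is a number no higher from compound 2 to compound 3 (the limit leaves the size open). In this assay, the estimate for compound 3 is 100 ug/mL, with an expected range from 50 ug/mL to 200 ug/mL.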

Compound 3, half-maximal inhibitory concentration: 2.5 ug/mL
Estimate against measurement, compound 3: 40-fold (1.60 log units) above; the whole stated range lies above it.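

At the saturated ring carbon, the group carried there can bring the shared core out of the limit in this assay, which is a limit and not a number: the limit of > 100 ug/mL in this assay, at which 2 of the 3 values shown sit. The sharpest comparison is nitro in place of hydrogen on an aromatic carbon, a single small change that gives an at least 40-fold lower number from compound 1 to compound 3 (1.60 log units; beyond the scatter). Replacing the whole group, 4-nitrophenyl in place of 2-phenylethenyl, gives an at least 40-fold lower number from compound 2 to compound 3 (1.60 log units; beyond the scatter), so both comparisons point the same way, though each has a limit at one end.

The compounds shown do not tell whether the nitro group is special, since an amine, a carboxylic acid or a chlorine atom on that phenyl ring could behave differently. The step between the two limits still cannot be read, so nothing separates phenyl from 2-phenylethenyl.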